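The compounds below may be only part of what the source reports. "The series", "measured", "known", "first", "only" and "open" are said of these compounds alone.

Measured compounds:
compound 1, `COc1ccc(SCc2ccc(/C=C/C(=O)Nc3ccccc3N)cc2)cc1OC` — 46.4%
compound 2, `Nc1ccccc1NC(=O)c1ccc(CSc2ccc(Br)cc2)cc1` — 6.17%

In a functional assay on A-375 cells (Homo sapiens) for inhibition, read by CCK-8 assay, with a stated time of 72 h, tested at 8 uM (a lower number here means less inhibition of growth, a higher number more inhibition of growth at the concentration tested), compound 1 gives 46.4%, the higher of the two numbers recorded. Compound 2 gives 6.17%, a number lower by an amount that lies beyond the scatter. Going by the values given here, compound 2 differs from compound 1 in more than one place, so no single step between the two is counted, and the pair shows only what its two values show.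

Compound 3, `Nc1ccccc1NC(=O)/C=C/c1ccc(CSc2ccc(Cl)cc2)cc1`, has not yet been measured. It differs from compound 1 as follows: 4-chlorophenyl in place of 3,4-dimethoxyphenyl on a sulfur. Among the compounds with values here, no measured step of this kind exists in the set, so the expectation rests on the values of compounds 1 and 2 alone. The step of a number 14.4 percentage points lower from compound 1 to compound 3 (beyond the scatter) is expected to be a decrease beyond the scatter. For compound 3 the estimate in this assay is 32%, with a range from 12% to 55%.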

Compound 3, percent growth inhibition at one concentration: 48.2%
Compound 3: middle estimate off by 16.2 percentage points, on the low side; measured number inside the range.
By their numbers in this assay, from the lowest: compound 2; then compounds 1 and 3 (each within the scatter of the next).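

In this assay, going by these compounds alone, putting 4-chlorophenyl in place of 3,4-dimethoxyphenyl on a sulfur gives a number 1.8 percentage points higher from compound 1 to compound 3 (within the scatter), the first step that can be read at this place. The two groups cannot be told apart by this number, although they differ in heavy atoms and hydrogen-bond acceptors, so the two acceptors of the 3,4-dimethoxyphenyl are not needed to keep this level of growth inhibition in this pair. No evidence on why the two compounds match is available.

Going by these compounds, whether an amine or a carboxylic acid on that ring would keep this level remains open. So does the effect of a longer chain on the sulfur, and compound 2, at 6.17%, differs from compound 1 in more than one place, so its number cannot be assigned to any one change.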